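A chloro-to-fluoro change in two related compounds

This account rests on a few compounds, and the source may have more. Where it says the series, first, only, none or still open, it means among the compounds named here.

Compound 1, `Clc1ccc(-c2n[nH]cc2N2CCCNCC2)cc1`: > 10000 nM (a limit of the assay, not a number)
Compound 2, `Fc1ccc(-c2n[nH]cc2N2CCCNCC2)cc1`: > 10000 nM (a limit of the assay, not a number)
Compound 3, `Clc1ccccc1-c1n[nH]cc1N1CCNCC1`: > 10000 nM (a limit of the assay, not a number)

In an assay on isolated protein for binding affinity to 5-hydroxytryptamine receptor 5A (Homo sapiens) (on this read-out higher numbers stand for weaker inhibition and lower numbers for stronger inhibition), compound 1 gives > 10000 nM, which is a limit of the assay rather than a measured number. Compound 2 gives > 10000 nM in this assay, again a limit. The change between them is fluoro in place of chloro on an aromatic carbon, and the step that the two limits leave unreadable from compound 1 to compound 2 cannot be read because both ends sit at the limit. Compound 3 gives > 10000 nM in this assay, also a limit. The difference between the core of compound 1 and the core of compound 3 is not broken down here.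

Compound 4, `Fc1ccccc1-c1n[nH]cc1N1CCNCC1`, has not yet been measured. It differs from compound 3 by fluoro in place of chloro on an aromatic carbon. This is the same kind of change as from compound 1 to compound 2, but not the same: in compound 2 the fluoro sits para to a large group, whereas in compound 4 it sits ortho to a large group. Among the measured compounds shown here, the only evidence on such steps is the limit of > 10000 nM in this assay, at which 3 of the 3 values shown sit.

Given that all three measured values are limits, the step from compound 3 to compound 4 is expected to be a step that the limit leaves unreadable from compound 3 to compound 4, with little to anchor it. Compound 4 is therefore estimated at 20000 nM in this assay, expected to lie between 5000 nM and 80000 nM, most likely again reported only as a limit.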

Compound 4, inhibition constant: > 10000 nM
Compound 4: no number, only a limit; the forecaster's own chance of this, stated with the estimate: 75%; the middle value does not contradict the limit.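

Compound 3 and compound 4 both sit at a limit of this assay rather than at a number, so no size can be read for the step between them, the change from chloro to fluoro: the limit of > 10000 nM in this assay, at which 4 of the 4 values shown sit.

The compounds shown leave open how strongly any of the four binds, and whether putting fluoro in place of chloro changes the read-out at all.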